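Compound 3 to compound 4: replacing the 4-methylphenyl group

The compounds below may be only part of what the source reports. "The series", "measured", "known", "first", "only" and "open" are said of these compounds alone.

Measured in an ADME assay (liver, Mus musculus) for metabolic stability, using microsomes; on this read-out higher numbers stand for a longer-lived compound and lower numbers for a shorter-lived compound:
- compound 1 `Cc1nc2ccc(Cl)cn2c1C(=O)NCc1ccc(-c2ccccc2)cc1`: > 1 h (a limit of the assay)
- compound 2 `CCc1nc2ccc(Cl)cn2c1C(=O)NCc1ccc(-c2ccc(C)cc2)cc1`: 0.677 h
- compound 3 `CCc1nc2cc(Cl)ccn2c1C(=O)NCc1ccc(-c2ccc(C)cc2)cc1`: 0.385 h

Compound 3 gives 0.385 h and compound 2 gives 0.677 h, and these two numbers lie within the scatter of each other. Compound 1 is reported as > 1 h, which is a limit and not a number.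

The next compound to be tested is compound 4 `CCc1nc2cc(Cl)ccn2c1C(=O)NCc1ccc(-c2ccc[nH]2)cc1`. Starting from compound 3, it carries 1H-pyrrol-2-yl in place of 4-methylphenyl on an aromatic carbon. The substituent sits on a six-membered aromatic ring of carbon only, para to a large group.

Among the compounds with values here, no pair of measured compounds differing in one place is available, so the series offers no direct precedent for this change. The working expectation therefore stays close to compound 3 at 0.385 h, with no clear direction and no shift beyond the scatter. The expected move is a 1.1-fold lower number from compound 3 to compound 4 (0.04 log units; within the scatter). The range is kept wide, since the new group has not been tested in this series. In this assay, compound 4 is expected at 0.35 h, with an estimated range of 0.13 h to 0.9 h.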

Compound 4, half-life: 0.18 h
The estimate for compound 4 lay 1.9-fold (0.29 log units) above the measured number; the range from low to high includes it.
By their numbers in this assay, from the lowest: compound 4; then compounds 3 and 2 (each within the scatter of the next). At a limit, above all of these: compound 1.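

In this assay, within the data shown here, 1H-pyrrol-2-yl in place of 4-methylphenyl on an aromatic carbon gives a 2.1-fold lower number from compound 3 to compound 4 (0.33 log units; beyond the scatter), the first step between compounds that differ in one place. The half-life therefore responds to the group at this place, on the six-membered aromatic ring of carbon only and para to a large group, and this exchange moves it towards a shorter-lived compound. The exchange changes ring size, heavy atom count and hydrogen-bond donor count together, the single step does not separate these, and no measurement shown bears on why the number falls.

Open, as far as these compounds go, is how a 1-methyl-1H-pyrrol-2-yl group, a pyridyl ring or a carboxylic acid on the same aromatic carbon would read in this assay, and with that whether the shorter half-life goes with the hydrogen-bond donor or with the smaller ring. Also open, from the compounds shown here alone, is whether the same exchange gives a step of like size on the core of compound 2.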